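Swapping the ring-nitrogen substituent in a phthalazinone-like series

This account rests on a few compounds, and the source may have more. Where it says the series, first, only, none or still open, it means among the compounds named here.

Measured compounds:
- compound 1, `O=c1c2ccccc2c(Nc2n[nH]c3ccccc23)nn1-c1ccccc1`: "not determined" (no result reported)
- compound 2, `COc1ccc(-n2nc(Nc3cc(C)[nH]n3)c3ccccc3c2=O)cc1`: 3700 nM

Compound 1 carries an unsubstituted phenyl on the ring nitrogen and a larger fused amine, but in a functional assay on COLO 205 cells (Homo sapiens) for cytotoxicity (on this read-out higher numbers stand for weaker inhibition and lower numbers for stronger inhibition), compound 1 gives "not determined" (no result reported). Compound 2 therefore provides the only figure available: in this assay compound 2 gives 3700 nM. With a single number, compound 2 neither leads nor trails anything; it is simply the reference point.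

Compound 3, `Cc1cc(Nc2nn(Cc3cc(F)ccc3F)c(=O)c3ccccc23)n[nH]1`, is not yet measured. It differs from compound 2 in one place: 2,5-difluorobenzyl in place of 4-methoxyphenyl on an aromatic nitrogen. The group that leaves sits on an aromatic nitrogen of a six-membered aromatic ring with two nitrogens, part of a fused system of two rings; the group that enters occupies the same spot. Within the data shown here, no measured pair shows what this kind of exchange does, so the direction is open.

Compound 3 is expected to land near compound 2, with a step of a 1.2-fold lower number from compound 2 to compound 3 (0.09 log units; within the scatter) that would not clearly exceed the scatter, giving an estimated 3000 nM, likely between 800 nM and 12000 nM.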

Compound 3, half-maximal inhibitory concentration: 3800 nM
Compound 3: middle estimate off by 1.3-fold (0.10 log units), on the low side; the measured number falls inside the stated range.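

In this assay, putting 2,5-difluorobenzyl in place of 4-methoxyphenyl on the aromatic nitrogen gives a 1.0-fold higher number from compound 2 to compound 3 (0.01 log units; within the scatter) and so leaves the two compounds indistinguishable. Among these compounds, this is the first measured exchange at this position, and it shows that, for this one pair, the number holds even though the entering group differs in several ways: the ring is now a benzyl rather than a phenyl, two fluorines replace the methoxy, and the hydrogen-bond acceptor counted in the leaving group is absent from the entering one. No supporting measurement is available that would account for this outcome.

Since these differences arrive together, the pair cannot say whether any one of them matters on its own or whether they offset one another; a plain benzyl or an unsubstituted phenyl on the same nitrogen, paired with the same (5-methyl-1H-pyrazol-3-yl)amino group, would begin to separate them. From the compounds shown here alone, it also remains open whether a different kind of group at this position, such as an amine, a carboxylic acid or a longer chain, would move the number beyond the usual scatter.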